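A Nitro Group Joins Two Inert Analogues

The source may report more compounds than this note shows. Statements on the series, on what has been measured and on what is new or still open speak of the compounds shown alone.

Compound 1 `Cc1cccc(Cn2cc(COc3ccc4c(=O)ccoc4c3)nn2)c1` is tested in an ADME assay on L02 cells (Homo sapiens) for cytotoxicity, read by MTT assay, with a stated time of 48 h (a lower number here means a stronger inhibitor, a higher number a weaker inhibitor), where compound 1 gives > 300000 nM, a limit of the assay rather than a number. Compound 2 `O=c1ccoc2cc(OCc3cn(Cc4ccc(F)cc4)nn3)ccc12` differs from compound 1 in one place, and in this assay compound 2 gives > 300000 nM, also a limit. The step that the two limits leave unreadable from compound 1 to compound 2 therefore cannot be read. Compound 3 `O=c1ccoc2cc(OCc3cn(Cc4ccc([N+](=O)[O-])cc4)nn3)ccc12` carries the change (4-nitrophenyl in place of 3-methylphenyl on a saturated chain carbon bound to an aromatic nitrogen). Both measured values sit at the same limit (the limit of > 300000 nM in this assay, at which 2 of the 2 values shown sit), so no direction is readable and no step beyond the scatter is expected. Compound 3 is expected to give 400000 nM, from 150000 nM to 1500000 nM. The expected step is a step that the limit leaves unreadable from compound 1 to compound 3.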

Compound 3, half-maximal inhibitory concentration: > 300000 nM
Compound 3: a limit, no number (the forecaster's own chance of this, stated with the estimate: 85%); the middle value does not contradict the limit.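

Compound 1, compound 2 and compound 3 all stop at a limit rather than a number, so no step among them can be read: the limit of > 300000 nM in this assay, at which 3 of the 3 values shown sit.

From the compounds shown here alone, whether these three compounds differ at all in this assay stays open.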